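A few compounds are considered here, and "the series" means these few. Any claim that something is new, unique, unknown or untested is made for them only; others in the source may bear on it.

Compound 1 `O=C(S[C@]12CCC[C@H]1C(=O)NC2=O)c1ccccc1Cl`: 59800 nM
Compound 2 `CC(=O)OC1CC[C@]2(SC(=O)c3ccc(F)cc3)C(=O)NC(=O)[C@H]12`: 34300 nM

In a functional assay on RAW264.7 cells (Mus musculus) for inhibition, read by Griess assay, with a stated time of 24 h (a lower number here means a stronger inhibitor, a higher number a weaker inhibitor), compound 2 gives 34300 nM, which lies within the scatter of compound 1 at 59800 nM. Compound 3 `CC(=O)OC1CC[C@]2(SC(=O)c3ccccc3Cl)C(=O)NC(=O)[C@H]12` keeps the core of compound 2 and changes one group: 2-chlorophenyl in place of 4-fluorophenyl on a carbonyl carbon. That is 2-chlorophenyl in place of 4-fluorophenyl on a carbonyl carbon. Compound 1 also carries 2-chlorophenyl, on a different core, and its 59800 nM gives no reason to expect a step beyond the scatter in this assay. The expected change is a 1.2-fold higher number from compound 2 to compound 3 (0.07 log units; within the scatter), which would stay within the scatter. Compound 3 is estimated at 40000 nM, with a range of 18000 nM to 90000 nM.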

Compound 3, half-maximal inhibitory concentration: 101000 nM
For compound 3 the middle estimate is 2.5-fold (0.40 log units) below the measured one; measured number above the stated range.
By their numbers in this assay, from the lowest: compounds 2, 1 and 3 (each within the scatter of the next, the first and the last beyond it).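

In this assay the group on the carbonyl carbon does matter: 2-chlorophenyl in place of 4-fluorophenyl gives a 2.9-fold higher number from compound 2 to compound 3 (0.47 log units; beyond the scatter) and so a modestly weaker inhibitor. With 2-chlorophenyl kept, acetoxy in place of hydrogen on a saturated ring carbon gives a 1.7-fold higher number from compound 1 to compound 3 (0.23 log units; within the scatter) and so no readable change. The two phenyl groups differ in both the halogen and its place on the ring, so 4-chlorophenyl, 2-fluorophenyl or plain phenyl would be needed to separate those two changes. No measurement shown here explains the step.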